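Working notes: the step from compound 3 to compound 4

The source may report more compounds than this note shows. Statements on the series, on what has been measured and on what is new or still open speak of the compounds shown alone.

Measured in a functional assay on B16-F10 cells (Mus musculus) for antiproliferative activity, read by CCK-8 assay, with a stated time of 48 h; on this read-out lower numbers stand for stronger inhibition and higher numbers for weaker inhibition:
- compound 1 `COc1ccc(/C=C\c2cc(OC)c(OC)c(OC)c2)cc1OCc1ccc(CN2C[C@H](O)C[C@@H]2C(=O)O)cc1`: > 10000 nM, a limit
- compound 2 `COc1ccc(/C=C\c2cc(OC)c(OC)c(OC)c2)cc1OCc1ccc(CN2CCCC[C@@H]2C(=O)O)cc1`: > 10000 nM, a limit
- compound 3 `COc1ccc(/C=C\c2cc(OC)c(OC)c(OC)c2)cc1OCc1ccc(CN2CCCCC2C(=O)O)cc1`: > 10000 nM, a limit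

Compound 3 gives only a limit, > 10000 nM. No ranking of the three compounds can be drawn from the limit of > 10000 nM in this assay, at which 3 of the 3 values shown sit.

Compound 4 `COc1ccc(/C=C\c2cc(OC)c(OC)c(OC)c2)cc1OCc1ccc(CN2CC(C(=O)O)C2)cc1` has not yet been measured. Its difference from compound 3 is 3-carboxyazetidin-1-yl in place of 2-carboxypiperidin-1-yl on a saturated chain carbon bound to an aromatic carbon. The group that changes sits on a saturated chain carbon bound to an aromatic carbon.

Two measured steps change the group at this same place: a step that the two limits leave unreadable from compound 1 to compound 2 and a step that the two limits leave unreadable from compound 1 to compound 3. A third, a step that the two limits leave unreadable from compound 2 to compound 3, concerns only (the fact that one of compounds 2 and 3 is drawn with a defined configuration and the other without, at the place where they differ). None of these steps has a readable size, so none gives a measure for the change to compound 4.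

Among the compounds with values here, compound 4 is expected to remain at the same limit in this assay, because the limit of > 10000 nM in this assay, at which 3 of the 3 values shown sit, shows no compound of the series reaching a number. The expected step is a step that the limit leaves unreadable from compound 3 to compound 4, with no direction that the data can fix. For compound 4 the estimated value is 12000 nM, with an expected range from 4000 nM to 30000 nM.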

Compound 4, half-maximal inhibitory concentration: > 10000 nM
Compound 4: no number, only a limit (the forecaster's own chance of this, stated with the estimate: 85%); the middle value does not contradict the limit.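

In this assay compound 4 gives > 10000 nM, a limit and not a number. The steps to compound 4 from compounds 1, 2 and 3 cannot be read, because the series offers only this: the limit of > 10000 nM in this assay, at which 4 of the 4 values shown sit.

The compounds shown leave open whether any group on the saturated chain carbon bound to an aromatic carbon gives a measurable value in this assay.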